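Anilide in Place of Aryl Ketone on a Triazole Scaffold

The source may hold more compounds than are shown below. What is called first, only, known or untested is meant among the compounds shown, and "the series" means these compounds.

Compound 1 `COc1cc(-c2nnc(SCC(=O)c3ccc(Cl)cc3)n2N)cc(OC)c1OC` has only a limit in a functional assay on HepG2 cells (Homo sapiens) for antiproliferative activity, read by MTT assay, with a stated time of 48 h (on this read-out lower numbers stand for stronger inhibition and higher numbers for weaker inhibition), namely > 100000 nM, as the limit of > 100000 nM in this assay, at which 1 of the 2 values shown sits, records. Among the compounds with values here, compound 2 `COc1cc(-c2nnc(SCC(=O)c3ccc(Br)cc3)n2N)cc(OC)c1OC` is the one compound with a number here, giving 92500 nM in this assay. Within the data shown here, the only measured step is an at least 1.0-fold lower number from compound 1 to compound 2 (0.03 log units; that floor lies within the scatter), a bromo in place of chloro on an aromatic carbon, which lies within scatter. Compound 3 `COc1cc(-c2nnc(SCC(=O)Nc3ccccc3C)n2N)cc(OC)c1OC` differs from compound 2 by (2-methylphenyl)amino in place of 4-bromophenyl on a carbonyl carbon. Among the measured compounds shown here, no measured step resembles this change, so no shift beyond the scatter is expected, meaning a step of a 1.0-fold lower number from compound 2 to compound 3 (0.01 log units; within the scatter). Compound 3 is therefore estimated at 90000 nM, between 30000 nM and 300000 nM.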

Compound 3, half-maximal inhibitory concentration: > 100000 nM
Compound 3 ended at the assay's limit; the forecaster's own chance of this, stated with the estimate: 50%; middle value at least 1.1-fold (0.04 log units) from the limit.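

Replacing 4-bromophenyl with (2-methylphenyl)amino on the carbonyl carbon turns the aryl ketone into an anilide and gives an at least 1.0-fold higher number from compound 2 to compound 3 (0.03 log units; that floor lies within the scatter) in this assay, so this change shows no sign of stronger inhibition. Compound 3 gives > 100000 nM as a limit of the assay, not a number. The step between compound 1 and compound 3 cannot be read, and the values gather at one ceiling: the limit of > 100000 nM in this assay, at which 2 of the 3 values shown sit.

From the compounds shown here alone, it remains open whether a carboxylic acid or a simple amine on this carbonyl carbon would give a readable number.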